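The compounds below may be only part of what the source reports. "The series", "measured", "known", "first", "only" and "open" are said of these compounds alone.

Values in a functional assay on HepG2 cells (Homo sapiens) for inhibition, read by MTT assay, with a stated time of 72 h (a higher number here means a weaker inhibitor, a lower number a stronger inhibitor), for the three measured compounds:

Compound 1, `CC(C)c1ccccc1-n1cc(COc2cccc(NC(=O)Nc3ccc(Cl)c(C(F)(F)F)c3)c2)nn1`: 1900 nM
Compound 2, `CC(C)c1cccc(-n2cc(COc3cccc(NC(=O)Nc4ccc(Cl)c(C(F)(F)F)c4)c3)nn2)c1`: 3250 nM
Compound 3, `O=C(Nc1cccc(OCc2cn(-c3ccc(F)cc3)nn2)c1)Nc1ccc(Cl)c(C(F)(F)F)c1`: 1350 nM

All three share one core and differ only in the aryl group on the aromatic nitrogen of the triazole. Compound 3 gives the lowest number of the three in this assay; its nearest neighbour is compound 1, separated by a 1.4-fold lower number from compound 1 to compound 3 (0.15 log units; within the scatter), which is within the scatter, while compound 2 lies furthest away, with a 2.4-fold lower number from compound 2 to compound 3 (0.38 log units; beyond the scatter), a modest step beyond the scatter. The third comparison, a 1.7-fold higher number from compound 1 to compound 2 (0.23 log units; within the scatter), is again within the scatter.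

Compound 4, `O=C(Nc1cccc(OCc2cn(-c3ccccc3Br)nn2)c1)Nc1ccc(Cl)c(C(F)(F)F)c1`, has not yet been measured. It differs from compound 3 in one place: 2-bromophenyl in place of 4-fluorophenyl on an aromatic nitrogen. Among the measured compounds shown here, the steps that bear on this change are those in which the aryl group on the same nitrogen was varied, namely the steps from compound 1 to compound 3 and from compound 2 to compound 3. Both were small, and only one of them crossed the scatter. On that basis compound 4 is expected to stay close to compound 3, with an expected step of a 1.3-fold higher number from compound 3 to compound 4 (0.10 log units; within the scatter) and no movement beyond the scatter. The estimate for compound 4 in this assay is 1700 nM, with an expected range from 800 nM to 3600 nM.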

Compound 4, half-maximal inhibitory concentration: 2810 nM
Compound 4: the middle estimate sits 1.7-fold (0.22 log units) below what was measured; the measured number falls inside the stated range.
By their numbers in this assay, from the lowest: compounds 3, 1, 4 and 2 (each within the scatter of the next, the first and the last beyond it).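

In this assay, the step of a 2.1-fold higher number from compound 3 to compound 4 (0.32 log units; beyond the scatter) gives a second aryl group on this nitrogen that lies beyond the scatter from the 4-fluorophenyl group of compound 3, and the earlier step between compound 2 and compound 3 no longer stands alone, although compound 1 remains within the scatter of compound 3. The new compound also allows a change of a single substituent on the aryl ring, and bromo in place of isopropyl gives a 1.5-fold higher number from compound 1 to compound 4 (0.17 log units; within the scatter), while the step of a 1.2-fold lower number from compound 2 to compound 4 (0.06 log units; within the scatter) shows that 2-bromophenyl and 3-isopropylphenyl also remain within the scatter of each other. No measurement is available here to explain any of these differences.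

Since 4-fluorophenyl and 2-bromophenyl differ in both the halogen and its place on the ring, the compounds shown cannot tell which of the two accounts for the step from compound 3. They also leave open how this nitrogen would tolerate an unsubstituted phenyl group, or an aryl group carrying an amine or a carboxylic acid.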